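The source may report more compounds than this note shows. Statements on the series, on what has been measured and on what is new or still open speak of the compounds shown alone.

Two members of this series have been measured in a functional assay on MGC-803 cells (Homo sapiens) for cytotoxicity, read by MTT assay, with a stated time of 48 h; on this read-out lower numbers stand for stronger inhibition and higher numbers for weaker inhibition. Compound 1 `CC1=NN(C(=O)CN2CCCCC2)C(c2ccccc2O)C1`, carrying piperidin-1-yl on a saturated chain carbon bound to a carbonyl carbon, gives 4310 nM. Compound 2 `CC1=NN(C(=O)CN2CCCC2)C(c2ccccc2O)C1`, with pyrrolidin-1-yl at that place, gives 17900 nM and so holds the higher, weaker number of the two. Compound 3 `CC1=NN(C(=O)CN2CCN(C)CC2)C(c2ccccc2O)C1` has not yet been measured. It keeps the shared core and exchanges that group for 4-methylpiperazin-1-yl: 4-methylpiperazin-1-yl in place of pyrrolidin-1-yl on a saturated chain carbon bound to a carbonyl carbon. Going by the values given here, only one measured step bears on this change, at the same place on the chain: a 4.2-fold higher number from compound 1 to compound 2 (0.62 log units; beyond the scatter). Among the compounds with values here, the incoming group resembles the piperidin-1-yl of compound 1, which gives 4310 nM, more than pyrrolidin-1-yl does, but no measured compound carries it. A move towards a lower number in this assay is therefore expected, though probably a smaller one than that single step. The expected change is a 2.2-fold lower number from compound 2 to compound 3 (0.35 log units; beyond the scatter). For compound 3 the estimated value is 8000 nM, with an expected range from 2500 nM to 25000 nM.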

Compound 3, half-maximal inhibitory concentration: 7850 nM
Compound 3: the middle estimate sits 1.0-fold (0.01 log units) above what was measured; the measured number falls inside the stated range.
By their numbers in this assay, from the lowest: compounds 1 and 3 (each within the scatter of the next); then compound 2.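

In this assay, the change on the saturated chain carbon bound to a carbonyl carbon now has a second measured step, a 2.3-fold lower number from compound 2 to compound 3 (0.36 log units; beyond the scatter), so the higher number of compound 2 is no longer set against compound 1 alone. The other new step, a 1.8-fold higher number from compound 1 to compound 3 (0.26 log units; within the scatter), gives no order for 4-methylpiperazin-1-yl and piperidin-1-yl at this place, which shows that this position tolerates the extra ring nitrogen and its methyl in this assay and leaves pyrrolidin-1-yl, the only five-membered ring of the three, alone on the side of the higher number. No measurement shown accounts for either step.

The compounds shown leave open whether morpholin-4-yl or an open-chain amine such as diethylamino at this place would stay with compounds 1 and 3 or move towards compound 2. They also leave open whether a longer chain carrying piperidin-1-yl or 4-methylpiperazin-1-yl would keep these numbers in this assay or shift them.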